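A few compounds are considered here, and "the series" means these few. Any claim that something is new, unique, unknown or untested is made for them only; others in the source may bear on it.

Compound 1 `O=C(O)COc1cccc(CCc2nc(-c3ccccc3)c(-c3ccccc3)o2)c1` gives 1200 nM in a functional assay for inhibition, with Homo sapiens as the target; on this read-out higher numbers stand for weaker inhibition and lower numbers for stronger inhibition.
Compound 2 `CCOC(=O)/C(=C\c1cccc(OCC(=O)OC)c1)c1nc(-c2ccccc2)c(-c2ccccc2)o1` gives 2000 nM in this assay.

Compound 1 holds the lower of the two numbers, and compound 2 sits close to it; the gap between them falls within the scatter, so the two cannot be separated on this read-out. For the measured compounds named here, no pair of measured compounds differs in a single place, and compound 2 differs from compound 1 in more than one place, so its value gives no direct reading on the change considered here.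

Compound 3 `O=C(O)COc1cccc(CC(c2ccsc2)c2nc(-c3ccccc3)c(-c3ccccc3)o2)c1` has not been measured. It arises from compound 1 by one change: thiophen-3-yl in place of hydrogen on a saturated chain carbon bound to an aromatic carbon and a saturated chain carbon. Without a measured pair that makes this same change, the size of the step cannot be read from the data. The expectation for compound 3 is a step of a 1.5-fold lower number from compound 1 to compound 3 (0.18 log units; within the scatter), a modest shift that may not exceed the scatter. Compound 3 is estimated at 800 nM, within 200 nM to 3000 nM.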

Compound 3, half-maximal inhibitory concentration: 20700 nM
For compound 3 the middle estimate is 26-fold (1.41 log units) below the measured one; measured number outside the range, above it.
By their numbers in this assay, from the lowest: compounds 1 and 2 (each within the scatter of the next); then compound 3.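

In this assay, thiophen-3-yl in place of hydrogen on this saturated chain carbon gives a 17-fold higher number from compound 1 to compound 3 (1.24 log units; beyond the scatter) and so much weaker inhibition. Among the earlier compounds no pair differed in a single place, so this is the first direct reading of one change, and it shows that this carbon does not take this ring without a large loss. Nothing available explains the loss.

One substituent cannot tell whether the loss belongs to thiophen-3-yl itself or would follow from any group on this carbon. A methyl group or a hydroxyl group in the same place would help separate these two readings, and the compounds shown leave open how either would behave.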